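This account rests on a few compounds, and the source may have more. Where it says the series, first, only, none or still open, it means among the compounds named here.

Compound 1 `N=C(NCCCc1c[nH]cn1)NCCSC(c1ccccc1)c1ccccn1`: 1
Compound 2 `N=C(NCCCc1c[nH]cn1)NCCCC(c1ccccc1)c1ccccn1`: 1

In a functional assay on cardiac atrium for agonist activity at histamine H2 receptor (Cavia porcellus) (on this read-out lower numbers stand for smaller maximal responses and higher numbers for larger maximal responses), compound 1 gives 1 and compound 2 gives 1; the two values lie within the scatter of each other, so neither can be set above the other. Compound 3 `N=C(NCCCc1c[nH]cn1)NCCCC(c1ccc(F)cc1)c1ccccn1` differs from compound 2 in one place: fluoro in place of hydrogen on an aromatic carbon. Within the data shown here, no measured pair shows this change, so there is no measured step to lean on. Since compound 2 already reaches the reference response with 1, the expected step of no change at the digits printed from compound 2 to compound 3 (within the scatter) is none beyond the scatter. Compound 3 is therefore estimated at 1, between 0.8 and 1.05.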

Compound 3, intrinsic activity: the largest response reached, as a fraction of the reference agonist's: 0.9
The estimate for compound 3 lay 0.10 above the measured number; measured number inside the range.
By their numbers in this assay, from the lowest: compounds 3, 1 and 2 (each within the scatter of the next).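

In this assay, the phenyl to 4-fluorophenyl change brings a number 0.10 lower from compound 2 to compound 3 (within the scatter) at this place, so fluoro can stand in place of hydrogen, para to a large group, with the maximal response held within the scatter. The earlier pair carried only hydrogen there and so could not show this. The compounds shown leave open whether a larger group at the same place, such as trifluoromethyl or an amine, would also keep the response within the scatter. No evidence at hand bears on this result or says what lies behind it.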